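The source may hold more compounds than are shown below. What is called first, only, known or untested is meant among the compounds shown, and "the series" means these compounds.

Compound 2 `O=c1ccoc2ccc(OCc3ccc(Br)cc3)cc12`: 95 nM
Compound 3 `O=c1ccoc2ccc(OCc3cccc(F)c3)cc12`: 1230 nM
Compound 1 `O=c1ccoc2ccc(OCCc3ccccc3)cc12`: 3120 nM

In an assay on microsomes for inhibition of Amine oxidase [flavin-containing] A (Homo sapiens), read by fluorescence and spectrophotometry, with a stated time of 20 min (on this read-out higher numbers stand for weaker inhibition and lower numbers for stronger inhibition), compound 2 gives the lowest number of the three; compound 3 stands higher by a margin beyond the scatter, and compound 1 further still. Compound 4 `O=c1ccoc2ccc(OCc3ccc(C(F)(F)F)cc3)cc12` has not been measured in this assay. It differs from compound 2 in one place: trifluoromethyl in place of bromo on an aromatic carbon, on an aromatic carbon of a six-membered aromatic ring of carbon only, para to a large group. For the measured compounds named here, no pair of measured compounds shows this exchange, so the expectation rests on compound 2 alone. The expected step is a 2.6-fold higher number from compound 2 to compound 4 (0.42 log units; beyond the scatter), a modest move toward weaker inhibition that may still lie within the scatter. Compound 4 is therefore estimated at 250 nM, within a range of 60 nM to 1000 nM.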

Compound 4, half-maximal inhibitory concentration: 879 nM
Beside the measured number, compound 4's estimate is 3.5-fold (0.55 log units) below it; the range from low to high includes it.
By their numbers in this assay, from the lowest: compound 2; then compounds 4 and 3 (each within the scatter of the next); then compound 1.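

In this assay, trifluoromethyl in place of bromo on this aromatic carbon, para to a large group, gives a 9.3-fold higher number from compound 2 to compound 4 (0.97 log units; beyond the scatter) and so moves toward weaker inhibition. This position therefore distinguishes between these two groups, with bromo giving the stronger inhibition of the pair. Nothing measured here explains the difference. The compounds shown leave open how chloro, methoxy or a nitrile would read on the same carbon. They also leave open whether the ring without any group there would fall nearer compound 2 or compound 4.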